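Series notes: benzyl replaced by phenyl on the fused core

A few compounds are considered here, and "the series" means these few. Any claim that something is new, unique, unknown or untested is made for them only; others in the source may bear on it.

Among the measured compounds shown here, in a functional assay on CCRF-CEM cells (Homo sapiens) for inhibition, read by cell counting, with a stated time of 3 days (a lower number here means a stronger inhibitor, a higher number a weaker inhibitor), compound 2 `C=C(Br)C(=O)Nc1cccc(-c2cn3nc(Cc4ccccc4)sc3n2)c1` gives 4200 nM and stands at the upper end of the two numbers so far, separated from compound 1 only within the scatter. For the measured compounds named here, compound 1 `C=C(Br)C(=O)Nc1cccc(-c2cn3nc(-c4ccc(CC)cc4)sc3n2)c1` gives 3400 nM in this assay, and the only measured step, a 1.2-fold higher number from compound 1 to compound 2 (0.09 log units; within the scatter), is within the scatter. Compound 3 `C=C(Br)C(=O)Nc1cccc(-c2cn3nc(-c4ccccc4)sc3n2)c1` differs from compound 2 by phenyl in place of benzyl on an aromatic carbon; the group sits on an aromatic carbon of the five-membered aromatic ring with two nitrogen and one sulfur, next to the ring nitrogen and next to the ring sulfur. The step of a 1.2-fold higher number from compound 1 to compound 2 (0.09 log units; within the scatter) is the one that bears on this change, since it exchanged one aryl group for another at the same place without moving this assay beyond the scatter. For compound 3 an expected step of a 1.1-fold higher number from compound 2 to compound 3 (0.03 log units; within the scatter) is therefore not beyond the scatter. Compound 3 is estimated at 4500 nM, with a range from 2000 nM to 10000 nM.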

Compound 3, half-maximal inhibitory concentration: 960 nM
Compound 3: the middle estimate sits 4.7-fold (0.67 log units) above what was measured; measured number outside the range, below it.
By their numbers in this assay, from the lowest: compound 3; then compounds 1 and 2 (each within the scatter of the next).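

In this assay this position proves sensitive to the group it carries, a sensitivity that the step between compound 1 and compound 2 gave no sign of: phenyl in place of benzyl on an aromatic carbon gives (a 4.4-fold lower number from compound 2 to compound 3 (0.64 log units; beyond the scatter)), and hydrogen in place of ethyl on an aromatic carbon gives (a 3.5-fold lower number from compound 1 to compound 3 (0.55 log units; beyond the scatter)). Both changes lead to the same compound, so the unsubstituted phenyl is set apart from the benzyl of compound 2 and from the 4-ethylphenyl of compound 1, which stay within the scatter of each other. Nothing at hand accounts for this difference.

On these data alone, it remains open whether a methoxy group, an amine or a carboxylic acid on the phenyl ring would keep the lower number. As far as these compounds go, it also remains open how a pyridine ring or a simple alkyl chain in place of the phenyl would read.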